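The source may report more compounds than this note shows. Statements on the series, on what has been measured and on what is new or still open speak of the compounds shown alone.

Measured so far in a functional assay on NALM-6 cells (Homo sapiens) for antiproliferative activity, read by MTT assay and trypan blue exclusion, with a stated time of 72 h; a higher number here means a weaker inhibitor, a lower number a stronger inhibitor:
Compound 1 `COC(=O)c1ccc(C2SCC(=O)N2c2ccc(N3CCN(Cc4cc(OC)c(OC)c(OC)c4)CC3)cn2)c(OC)c1` gives > 100000 nM as a limit
Compound 2 `COC(=O)c1ccc(C2SCC(=O)N2c2ccc(N3CCN(Cc4ccc(Cl)c(Cl)c4)CC3)cn2)c(OC)c1` gives > 100000 nM as a limit
Compound 3 `COC(=O)c1ccc(C2SCC(=O)N2c2ccc(N3CCNCC3)cn2)c(OC)c1` gives 9710 nM as a measured number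

Compound 2 has no number of its own: it stands with compound 1 on the ceiling of the series (the limit of > 100000 nM in this assay, at which 2 of the 3 values shown sit). Compound 4 `COC(=O)c1ccc(C2SCC(=O)N2c2ccc(N3CCN(S(=O)(=O)c4ccc(OC)cc4)CC3)cn2)c(OC)c1` carries (4-methoxyphenyl)sulfonyl in place of 3,4-dichlorobenzyl on an amine nitrogen in a ring.

Within the data shown here, two measured steps bear on this change, both at that same nitrogen. Among the measured compounds shown here, the first is a step that the two limits leave unreadable from compound 1 to compound 2 and gives no guide to size. The second is an at least 10-fold lower number from compound 2 to compound 3 (1.01 log units; beyond the scatter) and is large, but it leaves only hydrogen on the nitrogen. Compound 4 instead keeps an aromatic group there, as compound 1 and compound 2 do, and both of those sit at the limit. The new sulfonyl link has not been tested in this series, so only a modest move towards a lower number is expected, and nothing near the full drop seen with compound 3.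

The expected change is an at least 2.2-fold lower number from compound 2 to compound 4 (0.34 log units; beyond the scatter) and it remains uncertain. The estimate for compound 4 is 45000 nM with an expected range from 12000 nM to 100000 nM in this assay and a report of only a limit would be no surprise.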

Compound 4, half-maximal inhibitory concentration: 29400 nM
For compound 4 the middle estimate is 1.5-fold (0.18 log units) above the measured one; the range from low to high includes it.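

Compound 1 and compound 2 both carry a substituted benzyl group on the amine nitrogen in a ring, and each gives only a limit: the limit of > 100000 nM in this assay, at which 2 of the 4 values shown sit.

In this assay, among these compounds, compound 4 gives the first readable value with an aromatic group kept on that nitrogen, and exchanging 3,4-dichlorobenzyl for (4-methoxyphenyl)sulfonyl brings an at least 3.4-fold lower number from compound 2 to compound 4 (0.53 log units; beyond the scatter). A large group on this nitrogen therefore need not push the series to its ceiling, although the free nitrogen still keeps an edge over the sulfonyl group, with a 3.0-fold higher number from compound 3 to compound 4 (0.48 log units; beyond the scatter).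

Compound 4 changes the link to the nitrogen and the substituents on the aromatic ring at the same time, and the compounds shown do not separate these two changes. A 3,4-dichlorophenylsulfonyl group or a 4-methoxybenzyl group on that nitrogen would address this, while a methanesulfonyl or a benzoyl group would show whether the sulfonyl link needs its aromatic ring at all.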